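A few compounds are considered here, and "the series" means these few. Any claim that something is new, unique, unknown or untested is made for them only; others in the source may bear on it.

In an ADME assay on THP-1 cells (Homo sapiens) for cytotoxicity (a lower number here means that less compound is tolerated, a higher number that more compound is tolerated), compound 1 `COc1ccc(-n2cc(COc3ccc(/C=N/Nc4nc(-c5ccc(Cl)cc5)cs4)cc3)nn2)cc1` gives 38700 nM, and compound 2 `COc1ccc(-n2cc(COc3ccc(/C=N/Nc4nc(-c5cc6ccccc6oc5=O)cs4)cc3)nn2)cc1` gives 36300 nM. Among the measured compounds shown here, compound 2 therefore holds the lowest of the two numbers measured so far, yet its only neighbour, compound 1, lies within the scatter of it, so the two cannot be told apart on these data. For the measured compounds named here, the single measured step, a 1.1-fold lower number from compound 1 to compound 2 (0.03 log units; within the scatter), exchanged one group for another on an aromatic carbon of the shared core without moving the number beyond the scatter.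

Compound 3 `COc1ccc(-n2cc(COc3ccc(/C=N/Nc4nc(-c5ccc(-c6ccccc6)cc5)cs4)cc3)nn2)cc1` differs from compound 2 in that (a group of 12 heavy atoms (12 carbon; 2 six-membered aromatic rings of carbon only) in place of a group of 11 heavy atoms (9 carbon, 2 oxygen; one six-membered aromatic ring of carbon only, one six-membered aromatic ring with 1 hetero atom), on an aromatic carbon). Going by the values given here, the only measured step that bears on this change is the one from compound 1 to compound 2: it touched the same aromatic carbon of the shared core with a group of a similar size and left this assay within the scatter. On that basis no change beyond the scatter is expected here either. The expected step is therefore a 1.0-fold higher number from compound 2 to compound 3 (0.01 log units; within the scatter). The estimate for compound 3 in this assay is 37000 nM, with a range from 15000 nM to 90000 nM.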

Compound 3, half-maximal cytotoxic concentration: 35800 nM
The estimate for compound 3 lay 1.0-fold (0.01 log units) above the measured number, within the range that was stated.
By their numbers in this assay, from the lowest: compounds 3, 2 and 1 (each within the scatter of the next).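

With 4-phenylphenyl now at this position, on an aromatic carbon of a five-membered aromatic ring with 1 nitrogen and 1 sulfur, this assay gives a 1.0-fold lower number from compound 2 to compound 3 (0.01 log units; within the scatter), even though the group that leaves carries 2 hydrogen-bond acceptors and the group that enters carries none. The second reading, phenyl in place of chloro on an aromatic carbon, gives a 1.1-fold lower number from compound 1 to compound 3 (0.03 log units; within the scatter), so the three groups at this position cannot be told apart in this assay, whether the group ends in chloro, in a further phenyl, or is the fused ring system with its oxygen atoms. The data offer no measured explanation for this sameness.

Every group shown at this position contains a six-membered aromatic ring of carbon only and carries no net charge, so it remains open whether a carboxylic acid or an amine on that ring, or a short alkyl chain in place of the ring, would take the number beyond the scatter. The compounds also leave open whether any change elsewhere on the shared core would do so.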